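Swapping an amine substituent on two related quinone cores

The source may hold more compounds than are shown below. What is called first, only, known or untested is meant among the compounds shown, and "the series" means these compounds.

Compound 1 `O=C1C=C(NC2CCCCC2)C(=O)c2c1nc1n2[C@H]2OC[C@@H](O)[C@H]2OC1` carries a cyclohexyl group on an amine nitrogen attached to its core. In a functional assay on ECa-109 cells for inhibition, with ECa-109 cell line (Homo sapiens) as the target, read by sulforhodamine B assay (a lower number here means a stronger inhibitor, a higher number a weaker inhibitor), compound 1 gives > 16000 nM, which is a limit of the assay rather than a number. Compound 2 `CCOc1ccccc1NC1=CC(=O)c2nc3n(c2C1=O)[C@H]1OC[C@@H](O)[C@H]1OC3` differs from it by 2-ethoxyphenyl in place of cyclohexyl on an amine nitrogen. In this assay compound 2 gives 4630 nM. This change made an at least 3.4-fold lower number from compound 1 to compound 2 (0.53 log units; beyond the scatter); the size of that step is bounded by the limit of > 16000 nM in this assay, at which 2 of the 3 values shown sit.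

Compound 3 `O=C1C(NC2CCCCC2)=CC(=O)c2c1nc1n2[C@H]2OC[C@@H](O)[C@H]2OC1` is built from the same atoms as compound 1, joined differently; the difference between the two cores is not broken down here. In this assay compound 3 gives > 16000 nM, again a limit of the assay. Compound 4 `CCOc1ccccc1NC1=CC(=O)c2c(nc3n2[C@H]2OC[C@@H](O)[C@H]2OC3)C1=O`, not yet measured, differs from compound 3 by 2-ethoxyphenyl in place of cyclohexyl on an amine nitrogen, the same change as before at the same kind of place.

Compound 4 is expected to show an at least 2.6-fold lower number from compound 3 to compound 4 (0.42 log units; beyond the scatter), resting on the step from compound 1 to compound 2, an at least 3.4-fold lower number from compound 1 to compound 2 (0.53 log units; beyond the scatter). For compound 4 the estimate is 6000 nM, spanning 2000 nM to 20000 nM, with a real chance that only a limit is reported.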

Compound 4, half-maximal inhibitory concentration: 4320 nM
The estimate for compound 4 lay 1.4-fold (0.14 log units) above the measured number; the measured number falls inside the stated range.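

On the second core, 2-ethoxyphenyl in place of cyclohexyl on the amine nitrogen again moves this assay in the favourable direction, with an at least 3.7-fold lower number from compound 3 to compound 4 (0.56 log units; beyond the scatter). The change therefore carried over between these two cores, and in both cases the number fell beyond the usual scatter: the same change on two cores in this assay, an at least 3.4-fold lower number (0.53 log units; beyond the scatter) from compound 1 to compound 2 and an at least 3.7-fold lower number (0.56 log units; beyond the scatter) from compound 3 to compound 4; the limit leaves it open whether they differ. This does not give the true size of either step, show that the two steps are equal, or establish a rule for other cores, since compound 1 and compound 3 each sit at a limit rather than at a number: the limit of > 16000 nM in this assay, at which 2 of the 4 values shown sit.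

The compounds shown leave open whether the step comes from the aromatic ring or from the ethoxy chain, a question that a plain phenyl group or a methoxy group in place of the ethoxy could help to answer in this assay. They also leave open how a longer chain on that ring would read on either core.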